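The source may hold more compounds than are shown below. What is called first, only, known or untested is meant among the compounds shown, and "the series" means these compounds.

Measured so far in a functional assay on 786-0 cells (Homo sapiens) for cytotoxicity, read by sulforhodamine B assay, with a stated time of 48 h, tested at 0.01 uM; a higher number here means a weaker effect of the compound at the concentration tested, a lower number a stronger effect:
compound 1 `COc1cc(-c2cc(/C=C/C(=O)c3ccc(Cl)c(Cl)c3)[nH]n2)cc(OC)c1OC` gives 95%
compound 2 `COc1ccc(C(=O)/C=C/c2cc(-c3cc(OC)c(OC)c(OC)c3)n[nH]2)cc1OC` gives 96%

For the measured compounds named here, compound 2 and compound 1 lie within the scatter of each other; the only recorded step, a number 1 percentage points higher from compound 1 to compound 2 (within the scatter), is a change at the carbonyl side. Compound 3 `COc1cc(C(=O)/C=C/c2cc(-c3cc(OC)c(OC)c(OC)c3)n[nH]2)cc(OC)c1OC` differs from compound 2 by methoxy in place of hydrogen on an aromatic carbon, on the other aryl ring. Going by the values given here, no measured step bears on this change, and the single step seen is within the scatter, so no movement beyond the scatter is expected in this assay. For compound 3 the expected value is 95% (range 85% to 100%), an expected step of a number 1 percentage points lower from compound 2 to compound 3 (within the scatter).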

Compound 3, a percentage reported as activity, at one concentration (the size of the read-out at that concentration, not a potency): 101%
Estimate against measurement, compound 3: 6 percentage points below; measured number above the stated range.
By their numbers in this assay, from the lowest: compounds 1, 2 and 3 (each within the scatter of the next).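

In this assay, methoxy in place of hydrogen on the carbonyl-side aryl ring gives a number 5 percentage points higher from compound 2 to compound 3 (within the scatter), so this position carries the added group without a readable shift. For the compounds shown here, this is the first step at this site, and it separates nothing at the single concentration tested. No measurement bears on a cause for this result.

On these data alone, whether an amine or a carboxylic acid at this position would move the read-out beyond the scatter remains open. So does the outcome with a longer chain, such as ethoxy, in place of methoxy.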